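Restoring an amide hydrogen in a vitamin D receptor agonist series

This account rests on a few compounds, and the source may have more. Where it says the series, first, only, none or still open, it means among the compounds named here.

In an assay on cells for agonist activity at vitamin D3 receptor (Homo sapiens), with a stated time of 96 h (a higher number here means that more compound is needed for the effect, a lower number that less compound is needed), compound 1 `CCN(CC)CCNC(=O)c1ccc(C(CC)(CC)c2ccc(OCCC(O)(CC)CC)c(C)c2)n1CC` gives 2.3 nM, compound 2 `CCOC(=O)C(CC(=O)OC)NC(=O)c1ccc(C(CC)(CC)c2ccc(OCCC(O)(CC)CC)c(C)c2)n1CC` gives 21 nM, and compound 3 `CCn1c(C(=O)N(C)CCO)ccc1C(CC)(CC)c1ccc(OCCC(O)(CC)CC)c(C)c1` gives 52.7 nM, the highest of the three numbers. Compound 4 `CCn1c(C(=O)NC(C)CO)ccc1C(CC)(CC)c1ccc(OCCC(O)(CC)CC)c(C)c1` differs from compound 3 only in the group on the carbonyl carbon: (1-(hydroxymethyl)ethyl)amino in place of (2-hydroxyethyl)(methyl)amino on a carbonyl carbon. Among the measured compounds shown here, no measured step makes exactly this change, but both earlier changes at the same carbonyl carbon were sizeable: a 23-fold higher number from compound 1 to compound 3 (1.36 log units; beyond the scatter) and a 2.5-fold higher number from compound 2 to compound 3 (0.40 log units; beyond the scatter). Both compounds 1 and 2, which give lower numbers than compound 3, carry an amide hydrogen, as compound 4 does. A modest drop in this assay is therefore expected, a 2.6-fold lower number from compound 3 to compound 4 (0.42 log units; beyond the scatter). Compound 4 is estimated at 20 nM, within a range of 6 nM to 70 nM.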

Compound 4, half-maximal effective concentration: 96 nM
Compound 4: the middle estimate sits 4.8-fold (0.68 log units) below what was measured, outside the stated range (above it).
By their numbers in this assay, from the lowest: compound 1; then compound 2; then compounds 3 and 4 (each within the scatter of the next).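

In this assay, an amide hydrogen on its own does not bring the number down at this carbonyl carbon: swapping (2-hydroxyethyl)(methyl)amino for (1-(hydroxymethyl)ethyl)amino gives a 1.8-fold higher number from compound 3 to compound 4 (0.26 log units; within the scatter). Compound 4 carries that hydrogen just as compounds 1 and 2 do, yet a 4.6-fold higher number from compound 2 to compound 4 (0.66 log units; beyond the scatter) and a 42-fold higher number from compound 1 to compound 4 (1.62 log units; beyond the scatter), so the rest of the group on the amide-type nitrogen matters as well. No evidence at hand explains these gaps.

From the compounds shown here alone, it remains open whether a 2-aminoethyl or 2-(dimethylamino)ethyl group on that nitrogen would come close to compound 1. A carboxylic acid in place of the ester groups of compound 2 is equally untested here.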